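A few compounds are considered here, and "the series" means these few. Any claim that something is new, unique, unknown or untested is made for them only; others in the source may bear on it.

Of the compounds shown here, three have so far been tested in a functional assay on MCF7 cells (Homo sapiens) for inhibition, read by sulforhodamine B assay, with a stated time of 48 h, tested at 50 uM; on this read-out higher numbers stand for more inhibition of growth at the one concentration tested and lower numbers for less inhibition of growth. Compound 1 `COc1cc2c(cc1CC=C(C)C)C(=O)C[C@@H](c1ccc(Oc3cccc([N+](=O)[O-])c3)cc1)O2` gives 53% and compound 3 `COc1cc2c(cc1CC=C(C)C)/C(=N/O)C[C@@H](c1ccc(O)cc1)O2` gives 93%. Compound 2 `COc1ccc([C@@H]2C/C(=N/OCc3cn(-c4cccc(CO)c4)nn3)c3cc(CC=C(C)C)c(OC)cc3O2)cc1` gives 42%, the lowest of the three numbers; compound 1 stands nearest, a gap beyond the scatter, and compound 3 stands furthest, also beyond the scatter. Compound 4 `COc1ccc([C@@H]2C/C(=N/OCc3cn(-c4cc(OC)c(OC)c(OC)c4)nn3)c3cc(CC=C(C)C)c(OC)cc3O2)cc1` has not yet been measured. It differs from compound 2 in one place: 3,4,5-trimethoxyphenyl in place of 3-(hydroxymethyl)phenyl on an aromatic nitrogen. Within the data shown here, no measured pair isolates this change, so nothing is known about its effect here. The expectation is that the step of a number 3 percentage points higher from compound 2 to compound 4 (within the scatter) stays small, with no direction beyond the scatter. Compound 4 is therefore estimated at 45%, within a range from 25% to 65%.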

Compound 4, percent growth inhibition at one concentration: 45%
For compound 4 middle estimate and measured number coincide at the digits printed; low and high end bracket the measured number.
By their numbers in this assay, from the lowest: compounds 2, 4 and 1 (each within the scatter of the next, the first and the last beyond it); then compound 3.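

Putting 3,4,5-trimethoxyphenyl in place of 3-(hydroxymethyl)phenyl on an aromatic nitrogen gives, in this assay, a number 3 percentage points higher from compound 2 to compound 4 (within the scatter). This position therefore accepts both groups with results that cannot be told apart, although the entering group has 12 heavy atoms against 8 and no hydrogen-bond donor. No outside measurement bears on why these two compounds read alike. Still open, as far as these compounds go, is how an unsubstituted phenyl, or a phenyl carrying an amine or a carboxylic acid, would read at this position. A simple methyl on that nitrogen also remains an open case.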